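Lengthening the Chain and Swapping the Amine

The source may hold more compounds than are shown below. What is called first, only, known or untested is meant among the compounds shown, and "the series" means these compounds.

Measured so far:
compound 1 `CN(C)CCCCCn1c2c(c3ccccc31)C(=O)c1c[n+]([O-])c3ccccc3c1C2=O`: 210 nM
compound 2 `CN1CCN(CCCCn2c3c(c4ccccc42)C(=O)c2c[n+]([O-])c4ccccc4c2C3=O)CC1`: 90 nM
compound 3 `O=C1c2c[n+]([O-])c3ccccc3c2C(=O)c2c1c1ccccc1n2CCN1CCCCC1`: 1080 nM

All three share one core and differ only in the chain and the amine hanging from the aromatic nitrogen. In a functional assay on A549 cells (Homo sapiens) for cytotoxicity, read by MTT assay, with a stated time of 72 h (a higher number here means a weaker inhibitor, a lower number a stronger inhibitor), compound 1 gives 210 nM, the second highest of the three numbers. Its nearest neighbour is compound 2, reached by a 2.3-fold lower number from compound 1 to compound 2 (0.37 log units; beyond the scatter); its furthest is compound 3, reached by a 5.1-fold higher number from compound 1 to compound 3 (0.71 log units; beyond the scatter).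

Compound 4 `CN1CCN(CCCCCCn2c3c(c4ccccc42)C(=O)c2c[n+]([O-])c4ccccc4c2C3=O)CC1` is not yet measured. Relative to compound 1 the change is (4-methylpiperazin-1-yl)methyl in place of dimethylamino on a saturated chain carbon, five bonds along the chain from an aromatic nitrogen.

Two measured steps speak to this. The swap of the dimethylamino end for a 4-methylpiperazin-1-yl end, seen in a 2.3-fold lower number from compound 1 to compound 2 (0.37 log units; beyond the scatter), lowered the number modestly, beyond the scatter. The steps of a 5.1-fold higher number from compound 1 to compound 3 (0.71 log units; beyond the scatter) and a 12-fold higher number from compound 2 to compound 3 (1.08 log units; beyond the scatter) show that the compound with the shortest chain and a piperidin-1-yl end has the highest number, while the longer-chain compounds sit lower. Compound 4 carries both the 4-methylpiperazin-1-yl end and a chain longer than that of compound 1, so a modestly lower number is expected, roughly as in a 1.8-fold lower number from compound 1 to compound 4 (0.24 log units; within the scatter).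

For compound 4 the estimate in this assay is 120 nM, with a range from 50 nM to 300 nM.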

Compound 4, half-maximal inhibitory concentration: 330 nM
Compound 4: middle estimate off by 2.8-fold (0.44 log units), on the low side, outside the stated range (above it).
By their numbers in this assay, from the lowest: compound 2; then compounds 1 and 4 (each within the scatter of the next); then compound 3.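

In this assay the step of a 1.6-fold higher number from compound 1 to compound 4 (0.20 log units; within the scatter) shows that this change at this place, which brings in a six-membered ring with two nitrogens and a longer chain, leaves the two compounds indistinguishable, so a 4-methylpiperazin-1-yl end does not by itself give a lower number than a dimethylamino end. The two compounds with that same end differ only in chain length, and the step of a 3.7-fold higher number from compound 2 to compound 4 (0.56 log units; beyond the scatter) shows that the longer chain of compound 4 goes with a higher number, so a longer chain is not better here; yet the step of a 3.3-fold lower number from compound 3 to compound 4 (0.51 log units; beyond the scatter) keeps compound 4 ahead of the short-chain piperidin-1-yl compound, although chain and amine both change in that pair. Nothing in the data explains why the numbers move this way.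

A chain longer than that of compound 4 would show whether the numbers keep climbing with length, and a morpholin-4-yl end would test another ring at the chain end. A piperidin-1-yl end on a longer chain would also help separate the share of the amine from that of the chain.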